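This account rests on a few compounds, and the source may have more. Where it says the series, first, only, none or still open, it means among the compounds named here.

Compound 1 `CCC(C)(C)Cc1c[nH]c(CCc2ccc(-c3csnn3)cc2)n1` gives 11 nM in a functional assay on HEK293 cells for agonist activity at Bombesin receptor subtype-3 (Mus musculus), read by luminescence and calcium flux, with a stated time of 10 min; a lower number here means that less compound is needed, a higher number that more compound is needed for the effect.
Compound 2 `CCC(C)(C)Cc1c[nH]c(CCc2ccc(-c3cccnc3)cc2)n1` gives 4.3 nM in this assay.
Compound 3 `CCC(C)(C)Cc1c[nH]c(CCc2ccc(-c3ccc(F)cn3)cc2)n1` gives 16 nM in this assay.

Compound 3 has the highest of the three numbers, though its gap to compound 1 is within the scatter and only its gap to compound 2 stands beyond it. Compound 4 `CCC(C)(C)Cc1c[nH]c(CCc2ccc(-n3cncn3)cc2)n1` has not yet been measured. It differs from compound 3 only at the group attached to the benzene ring of the shared core: 1H-1,2,4-triazol-1-yl in place of 5-fluoropyridin-2-yl on an aromatic carbon.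

For the measured compounds named here, two measured steps bear on this change, since both swap the same attached group. The step of a 1.5-fold higher number from compound 1 to compound 3 (0.16 log units; within the scatter) shows that going from a five-membered ring with hetero atoms to the 5-fluoropyridin-2-yl group barely moves the number, while a 3.7-fold higher number from compound 2 to compound 3 (0.57 log units; beyond the scatter) shows a modest rise for the other six-membered ring. Compound 4 brings back a five-membered ring rich in hetero atoms, much as in compound 1, whose value of 11 nM sits close to that of compound 3. On this basis the step of a 1.1-fold lower number from compound 3 to compound 4 (0.06 log units; within the scatter) is expected to stay within the scatter, with no clear direction. Compound 4 is therefore estimated at 14 nM in this assay, in a range from 5 nM to 45 nM.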

Compound 4, half-maximal effective concentration: 12 nM
Compound 4: middle estimate off by 1.2-fold (0.07 log units), on the high side; measured number inside the range.
By their numbers in this assay, from the lowest: compound 2; then compounds 1, 4 and 3 (each within the scatter of the next).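

In this assay, putting 1H-1,2,4-triazol-1-yl in place of 5-fluoropyridin-2-yl on the aromatic carbon para to a large group gives a 1.3-fold lower number from compound 3 to compound 4 (0.12 log units; within the scatter), so this site accepts a five-membered ring with 3 hetero atoms and 3 hydrogen-bond acceptors as readily as a six-membered ring with 1 of each. The comparison with the other five-membered ring gives a 1.1-fold higher number from compound 1 to compound 4 (0.04 log units; within the scatter), so these two rings cannot be told apart here, even though the triazole is joined through a ring nitrogen rather than a ring carbon. Against the pyridin-3-yl group the change gives a 2.8-fold higher number from compound 2 to compound 4 (0.45 log units; beyond the scatter), which leaves compound 2 with the lowest number of the four, while the three other rings stay together within the scatter.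

The data shown offer no explanation for why pyridin-3-yl stands apart. Plain pyridin-2-yl would help separate the effect of the ring nitrogen's place from that of the fluorine, and a non-ring group such as an amine or a carboxylic acid would test whether this carbon needs an aromatic ring at all.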